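The source may report more compounds than this note shows. Statements on the series, on what has been measured and on what is new or still open speak of the compounds shown alone.

Working notes on the series, read in a functional assay on SK-BR-3 cells (Homo sapiens) for cytotoxicity, read by MTT assay, with a stated time of 72 h; on this read-out higher numbers stand for weaker inhibition and lower numbers for stronger inhibition. Compound 1 `COc1cccc(CNC(=O)c2nc(Br)c3cccnc3c2N[C@H]2CC[C@H](N)CC2)c1` gives 6000 nM, and compound 2 `N[C@H]1CC[C@H](Nc2c(C(=O)NCc3ccc(F)cc3)nc(Br)c3cccnc23)CC1` gives 2000 nM, the lower of the two actual numbers. Compound 3 `N[C@H]1CC[C@H](Nc2c(C(=O)NCc3ccc(F)cc3)nc(N3CCCCC3)c3cccnc23)CC1` returns only a limit of the assay, > 10000 nM.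

Compound 4 `N[C@H]1CC[C@H](Nc2c(C(=O)NCc3ccc(Cl)cc3Cl)nc(Br)c3cccnc23)CC1` keeps the core and the bromo of compound 2 and carries 2,4-dichlorophenyl in place of 4-fluorophenyl on a saturated chain carbon bound to an amide-type nitrogen, (2,4-dichlorophenyl in place of 4-fluorophenyl on a saturated chain carbon bound to an amide-type nitrogen). Going by the values given here, the one measured change at this place is a 3.0-fold lower number from compound 1 to compound 2 (0.48 log units; beyond the scatter), where 4-fluorophenyl replaces 3-methoxyphenyl. The other measured change, an at least 5.0-fold higher number from compound 2 to compound 3 (0.69 log units; beyond the scatter), puts piperidin-1-yl in place of bromo on an aromatic carbon and does not bear on this exchange.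

Among the compounds with values here, the single precedent suggests that this place can move the number modestly, but it gives no direction for 2,4-dichlorophenyl. No step beyond the scatter is therefore expected in this assay. The estimated step is a 1.3-fold lower number from compound 2 to compound 4 (0.12 log units; within the scatter). For compound 4 the expected value is 1500 nM, with an estimated range of 500 nM to 4500 nM.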

Compound 4, half-maximal inhibitory concentration: 6000 nM
For compound 4 the middle estimate is 4.0-fold (0.60 log units) below the measured one; the whole stated range lies below it.
By their numbers in this assay, from the lowest: compound 2; then compounds 1 and 4 (each within the scatter of the next). At a limit, above all of these: compound 3.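

In this assay, 2,4-dichlorophenyl in place of 4-fluorophenyl on a saturated chain carbon bound to an amide-type nitrogen gives a 3.0-fold higher number from compound 2 to compound 4 (0.48 log units; beyond the scatter), so this place moves the number in a second exchange and not only with 3-methoxyphenyl. Two different groups now return the same reading, with no change at the digits printed from compound 1 to compound 4 (within the scatter), and among these three bromo compounds only the 4-fluorophenyl of compound 2 stands apart. Nothing at hand explains this step.

Open, on these data alone, is whether 4-chlorophenyl or unsubstituted phenyl would read with compound 2 or with compounds 1 and 4, which would separate the identity of the halogen from the presence of a second substituent. Also open, as far as these compounds go, is how an aminomethyl or carboxylic acid group on this phenyl ring would read.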